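The compounds below may be only part of what the source reports. "The series", "measured", "known", "first", "only" and "open" are said of these compounds alone.

Measured so far:
- compound 1, `C=CCN1C(=O)N(Cc2ccccc2)S(=O)(=O)n2cccc21`: > 802000 nM
- compound 2, `O=C1N(Cc2ccc(Cl)cc2Cl)c2cccn2S(=O)(=O)N1Cc1cccc(Br)c1`: > 243000 nM
- compound 3, `N#CCN1C(=O)N(Cc2ccccc2)S(=O)(=O)c2cscc21`: 503000 nM

All three compounds share one core and were tested in an ADME assay on MT4 cells (Homo sapiens) for cytotoxicity, read by MTT assay, with a stated time of 5 days; a higher number here means that more compound is tolerated, a lower number that less compound is tolerated. For compound 1 the result > 802000 nM is a limit of the assay, not a number. For compound 2 the result > 243000 nM is likewise a limit. Compound 3 gives a number, 503000 nM, in this assay. So compound 1 stands at the upper limit of what was tested, one of two compounds that reached a limit rather than a value, as the limit of > 802000 nM in this assay, at which 1 of the 3 values shown sits, and the limit of > 243000 nM in this assay, at which 1 of the 3 values shown sits, show.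

Compound 4, `N#Cc1cccc(CN2C(=O)N(Cc3ccccc3)S(=O)(=O)n3cccc32)c1`, has not yet been measured. It differs from compound 1 in one place: 3-cyanophenyl in place of vinyl on a saturated chain carbon bound to an amide-type nitrogen in a ring.

For the measured compounds named here, no step between two measured compounds is available here, so the expected size of the change rests on the measured values alone. Compound 3 shows that a compound of this core can give a number short of the limit in this assay. For compound 4, an intermediate value is expected, 350000 nM, with an expected range from 100000 nM to 900000 nM. The expected step of an at least 2.2-fold lower number from compound 1 to compound 4 (0.36 log units; beyond the scatter) would then be a modest decrease from the limit, though a further limit is quite possible.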

Compound 4, half-maximal cytotoxic concentration: > 318000 nM
Compound 4: a limit, no number; the forecaster's own chance of this, stated with the estimate: 45%; the middle value does not contradict the limit.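

In this assay compound 1 gives > 802000 nM, which is a limit and not a number. Compound 4 gives > 318000 nM, also a limit and not a number. The step between compound 1 and compound 4 therefore cannot be read. Going by these compounds, whether changing allyl to 3-cyanobenzyl alters the tolerated concentration at all remains open.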